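A few compounds are considered here, and "the series" means these few. Any claim that something is new, unique, unknown or untested is made for them only; others in the source may bear on it.

Measured compounds: compound 1 `CCSC(=O)C1=C(C)NC(=O)NC1c1ccoc1` with 1%; compound 2 `CC1=C(C(=O)SC(C)C)C(c2ccoc2)NC(=O)N1` with 3%; compound 3 `CCC(CC)OC(=O)C1=C(C)NC(=O)NC1c1ccoc1` with 5%.

All three were tested in an assay on membranes from HeLa cells for displacement of a labelled ligand from adenosine receptor A3 (Homo sapiens), read by scintillation counting, with a stated time of 180 min, tested at 1 uM; on this read-out lower numbers stand for less inhibition and higher numbers for more inhibition at the one concentration tested (going by the name of the read-out). Compound 2 and compound 1 are separated by hydrogen in place of methyl on a saturated chain carbon bound to a saturated chain carbon and a sulfur, and that step gave a number 2 percentage points lower from compound 2 to compound 1 (within the scatter). The core of compound 3 differs from that of compound 2 by (pentan-3-yl)oxy in place of isopropylsulfanyl on a carbonyl carbon, and the three values lie close together, as a number 4 percentage points higher from compound 1 to compound 3 (within the scatter) and a number 2 percentage points higher from compound 2 to compound 3 (within the scatter) show. Compound 4 `CCC(C)OC(=O)C1=C(C)NC(=O)NC1c1ccoc1` has not been measured; it differs from compound 3 by hydrogen in place of methyl on a saturated chain carbon, two bonds along the chain from an oxygen next to a carbonyl group. For the measured compounds named here, this is the same kind of change as the one from compound 2 to compound 1, though not the same: there the carbon is bound to a saturated chain carbon and a sulfur, here it lies two bonds along the chain from an oxygen next to a carbonyl group. Because a number 2 percentage points lower from compound 2 to compound 1 (within the scatter), the step of a number 1 percentage points lower from compound 3 to compound 4 (within the scatter) is expected to be small too. Compound 4 is therefore estimated at 4% in this assay, between -4% and 12%.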

Compound 4, a percentage reported as inhibition, at one concentration (the size of the read-out at that concentration, not a potency): 11%
For compound 4 the middle estimate is 7 percentage points below the measured one, and the stated range covers the measured number.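

In this assay compound 4 stays close to the other compounds, with a number 6 percentage points higher from compound 3 to compound 4 (within the scatter), a number 8 percentage points higher from compound 2 to compound 4 (within the scatter) and a number 10 percentage points higher from compound 1 to compound 4 (within the scatter). Replacing methyl with hydrogen on the chain gave steps on the two cores that cannot be told apart: the same change on two cores in this assay, a number 2 percentage points lower (within the scatter) from compound 2 to compound 1 and a number 6 percentage points higher (within the scatter) from compound 3 to compound 4, 8 percentage points apart, within the scatter of two such steps This gives no sign that the core alters the effect of the change, but it does not show that the change carries over, as neither step can be told from the scatter and only two cores are shown.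

The compounds shown leave open whether a longer chain or an amine in place of sec-butoxy would give a step beyond the scatter. As far as these compounds go, their potency also stays open, as the read-out covers one concentration.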